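Swapping Methyl for Cyclohexyl on an Aromatic Nitrogen

The source may report more compounds than this note shows. Statements on the series, on what has been measured and on what is new or still open speak of the compounds shown alone.

In a functional assay on brain (Rattus norvegicus, strain Wistar) for inhibition (on this read-out lower numbers stand for stronger inhibition and higher numbers for weaker inhibition), compound 3 `CCCc1ccc(-c2c(C)[nH]c(=O)n2C)cc1` gives 21500 nM and compound 2 `CCCCc1ccc(-c2c(C)[nH]c(=O)n2C2CCCCC2)cc1` gives 27100 nM. Among the compounds with values here, these two values lie within the scatter of each other and together form the low end of the numbers so far. Compound 1 `Cc1[nH]c(=O)n(C2CCCCC2)c1-c1ccccc1` gives 47600 nM, higher than compound 3 by more than the scatter.

The change to consider leads to compound 4 `CCCc1ccc(-c2c(C)[nH]c(=O)n2C2CCCCC2)cc1`, with cyclohexyl in place of methyl on an aromatic nitrogen. Within the data shown here, no measured pair makes this exchange. Among the measured compounds shown here, the only measured step is a 1.8-fold lower number from compound 1 to compound 2 (0.24 log units; within the scatter), made at a different place, so it bears on the question only indirectly. The closest guide is compound 2, which already carries cyclohexyl on an aromatic nitrogen and gives 27100 nM. A number near that one therefore seems likely, with no shift beyond the scatter. The expected change is a 1.4-fold higher number from compound 3 to compound 4 (0.14 log units; within the scatter). For compound 4 the estimated value is 30000 nM, with an expected range from 14000 nM to 60000 nM.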

Compound 4, half-maximal inhibitory concentration: 13900 nM
Beside the measured number, compound 4's estimate is 2.2-fold (0.33 log units) above it, and the stated range ends above it.
By their numbers in this assay, from the lowest: compounds 4, 3, 2 and 1 (each within the scatter of the next, the first and the last beyond it).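

In this assay, this aromatic nitrogen now has a direct measured exchange: cyclohexyl in place of methyl gives a 1.5-fold lower number from compound 3 to compound 4 (0.19 log units; within the scatter) and so shows no shift beyond the scatter, even though the entering group is much larger by heavy-atom count. Hydrogen in place of methyl at the end of the chain gives a 1.9-fold lower number from compound 2 to compound 4 (0.29 log units; within the scatter) and also stays within the scatter, whereas the addition of propyl, with cyclohexyl kept on the nitrogen, gives a 3.4-fold lower number from compound 1 to compound 4 (0.53 log units; beyond the scatter) and is the only one of these steps beyond it. Nothing available explains any of these steps.

On these data alone, it remains open whether an ethyl group, a phenyl ring or a chain ending in an amine or a carboxylic acid on this nitrogen would move the number beyond the scatter. As far as these compounds go, it is also open whether propyl on the aromatic carbon would give a similar step with methyl on the nitrogen.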